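Swapping benzyl for 4-methylphenyl on the sulfonyl group

The source may report more compounds than this note shows. Statements on the series, on what has been measured and on what is new or still open speak of the compounds shown alone.

Measured in a functional assay on HepG2 cells (Homo sapiens) for cytotoxicity, read by MTT assay; a higher number here means a weaker inhibitor, a lower number a stronger inhibitor:
Compound 1 `COc1ccc(/C=C/C(=O)c2ccc(OC)c3c2OC(C)(C)C=C3)cc1OC(=O)CCl`: 120 nM
Compound 2 `COc1ccc(/C=C/C(=O)c2ccc(OC)c3c2OC(C)(C)C=C3)cc1OS(=O)(=O)Cc1ccccc1`: > 10000 nM (a limit, not a number)

Compound 2 sits at the limit of > 10000 nM in this assay, at which 1 of the 2 values shown sits. Compound 3 `COc1ccc(/C=C/C(=O)c2ccc(OC)c3c2OC(C)(C)C=C3)cc1OS(=O)(=O)c1ccc(C)cc1` differs from it on a sulfonyl sulfur: 4-methylphenyl in place of benzyl on a sulfonyl sulfur. Among the measured compounds shown here, the only measured step is large, an at least 83-fold higher number from compound 1 to compound 2 (1.92 log units; beyond the scatter), and it brought in the sulfonyl link that compound 3 keeps. For the measured compounds named here, no measured step compares two sulfonyl groups, so no step beyond the scatter is expected in this assay. The expected change is an at least 1.2-fold lower number from compound 2 to compound 3 (0.09 log units; that floor lies within the scatter). For compound 3 the estimated value is 8000 nM, with an expected range of 2000 nM to 20000 nM.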

Compound 3, half-maximal inhibitory concentration: 3600 nM
Beside the measured number, compound 3's estimate is 2.2-fold (0.35 log units) above it, within the range that was stated.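

In this assay, the group on the sulfonyl sulfur makes a difference even with the sulfonyl link kept: 4-methylphenyl in place of benzyl gives an at least 2.7-fold lower number from compound 2 to compound 3 (0.44 log units; beyond the scatter). The reading for compound 2 is only a limit, so the true size of that step stays unknown: the limit of > 10000 nM in this assay, at which 1 of the 3 values shown sits.
Even so, (4-methylphenyl)sulfonyl falls well short of the (chloromethyl)carbonyl group, with a 30-fold higher number from compound 1 to compound 3 (1.48 log units; beyond the scatter).

Still open, from the compounds shown here alone, is how a methylsulfonyl group or a sulfonyl group with a longer chain would compare. An acetyl group in place of (chloromethyl)carbonyl would show whether the chlorine matters.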